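A few compounds are considered here, and "the series" means these few. Any claim that something is new, unique, unknown or untested is made for them only; others in the source may bear on it.

Going by the values given here, compound 1 `O=C(c1cn[nH]c1)N1CCC(C(=O)N2N=CCC2c2ccccc2)CC1` is the most polar of the three compounds measured so far: in a physicochemical assay for lipophilicity, read by HPLC, measured as chromatographic lipophilicity, at pH 7.4 (a higher number here means a more lipophilic compound, a lower number a more polar compound), compound 1 gives 2.1, while compound 2 `CC1=NN(C(=O)C(C)(C)C)[C@H](c2ccccc2)C1` gives 6.4 and compound 3 `CC(C)(C)C(=O)N1N=CCC1C1CCCCC1` gives 7.3, both far beyond the scatter above compound 1. Compound 4 `CC(=O)N1CCC(C(=O)N2N=CCC2c2ccccc2)CC1` has not yet been measured. It differs from compound 1 in one place: methyl in place of 1H-pyrazol-4-yl on a carbonyl carbon. Among the compounds with values here, no measured pair shows this change, so its size is not known from the data. A modest rise in this assay is expected, not more than a moderate step from compound 1, and it may fall within the scatter. The step from compound 1 to compound 4 is estimated at a number 0.50 log units higher from compound 1 to compound 4 (beyond the scatter). Compound 4 is therefore expected to give about 2.6, plausibly between 1.9 and 3.3.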

Compound 4, distribution coefficient: 2.5
The estimate for compound 4 lay 0.10 log units above the measured number; the measured number falls inside the stated range.
By their numbers in this assay, from the lowest: compound 1; then compound 4; then compound 2; then compound 3.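

Placing methyl in place of 1H-pyrazol-4-yl on a carbonyl carbon gives, in this assay, a number 0.40 log units higher from compound 1 to compound 4 (beyond the scatter), the first size seen for this change. The step is modest, although the swap takes away a five-membered aromatic ring with its hydrogen-bond donor and acceptor and leaves a single carbon. Nothing at hand accounts for the size of this step. The compounds shown leave open how an ethyl group, a longer chain or an amine would read on this carbonyl carbon. They also leave open whether the same change gives a similar step on another core.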